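Swapping 3-nitrophenyl for 2,3-dichlorophenyl on the shared core

A few compounds are considered here, and "the series" means these few. Any claim that something is new, unique, unknown or untested is made for them only; others in the source may bear on it.

Results in a functional assay on A549 cells (Homo sapiens) for cytotoxicity, read by MTT assay, with a stated time of 72 h; a higher number here means a weaker inhibitor, a lower number a stronger inhibitor:
Compound 1 `CNC(=O)c1cc(Oc2ccc(C(=O)/C=C/c3ccc(F)cc3Cl)cc2)ccn1`: 21100 nM
Compound 2 `CNC(=O)c1cc(Oc2ccc(C(=O)/C=C/c3ccc(C#N)cc3)cc2)ccn1`: 26400 nM
Compound 3 `CNC(=O)c1cc(Oc2ccc(C(=O)/C=C/c3cccc([N+](=O)[O-])c3)cc2)ccn1`: "not determined" (no result reported)

Compound 3 stands without a number in this assay, so the step to compound 4 `CNC(=O)c1cc(Oc2ccc(C(=O)/C=C/c3cccc(Cl)c3Cl)cc2)ccn1` has no measured starting point. The structural change is 2,3-dichlorophenyl in place of 3-nitrophenyl on a double-bonded chain carbon bound to a double-bonded chain carbon. Among the measured compounds shown here, only one measured step bears on it, and only indirectly, as an exchange of one substituted phenyl for another at the same place. That step runs a 1.3-fold higher number from compound 1 to compound 2 (0.10 log units; within the scatter), and it lies within the scatter. Two compounds are a thin basis, but they give no sign that such exchanges move the result beyond the scatter. The closest reference for compound 4 is compound 1, which also carries a chlorine-bearing phenyl and gives 21100 nM. No direction can be assigned to the change from compound 3, and no step beyond the scatter is expected from the values of the other two compounds. For compound 4 the estimated value is 22000 nM, with an expected range from 10000 nM to 45000 nM.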

Compound 4, half-maximal inhibitory concentration: > 50000 nM
Compound 4: no number, only a limit (the forecaster's own chance of this, stated with the estimate: 15%); middle value at least 2.2-fold (0.35 log units) away from the limit.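

The reading for compound 4 in this assay is a limit of the assay and not a number: the limit of > 50000 nM in this assay, at which 1 of the 4 values shown sits. With 2,3-dichlorophenyl in place of 2-chloro-4-fluorophenyl, the result is an at least 2.3-fold higher number from compound 1 to compound 4 (0.37 log units; beyond the scatter), so exchanging one substituted phenyl for another at this position can move the result past the scatter, which the earlier pair did not show. With 2,3-dichlorophenyl in place of 4-cyanophenyl, the result is an at least 1.8-fold higher number from compound 2 to compound 4 (0.27 log units; that floor lies within the scatter), and this floor alone does not establish a change beyond the scatter.

From the compounds shown here alone, how far compound 4 lies from the others remains unknown, and compound 3 has no number, so steps from it cannot be read. Going by these compounds, it also remains open whether an amine or a carboxylic acid on this phenyl would bring the result back towards that of compound 1.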